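The compounds below may be only part of what the source reports. "The series", "measured", "known", "first", "only" and "open" are said of these compounds alone.

In an assay on cells for inhibition of Amine oxidase [flavin-containing] B (Rattus norvegicus) (on this read-out higher numbers stand for weaker inhibition and lower numbers for stronger inhibition), compound 3 `O=C(Nc1ccc(F)c(Cl)c1)c1ccc2cn[nH]c2c1` gives 1070 nM. Compound 2 `O=C(NCc1ccc(Cl)c(Cl)c1)c1ccc2[nH]ncc2c1` gives 837 nM in this assay, and the two values lie within the usual scatter of each other. In this assay compound 1 `O=C(Nc1ccc2[nH]ncc2c1)c1c(F)cccc1Cl` gives > 10000 nM, which is a limit of the assay and not a number. That value is the limit of > 10000 nM in this assay, at which 1 of the 3 values shown sits. Compound 4 `O=C(Nc1ccc(F)c(F)c1)c1ccc2cn[nH]c2c1` has not yet been measured in this assay. It differs from compound 3 by fluoro in place of chloro on an aromatic carbon, ortho to a fluoro group and meta to a large group. No measured pair among these compounds shows this exchange. The step of a 1.9-fold higher number from compound 3 to compound 4 (0.27 log units; within the scatter) is expected to be modest, toward a higher number, possibly not beyond the scatter. Compound 4 is therefore estimated at 2000 nM, with a range from 800 nM to 6000 nM.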

Compound 4, half-maximal inhibitory concentration: < 10000 nM
Compound 4 ended at the assay's limit (the forecaster's own chance of this, stated with the estimate: 10%); the middle value does not contradict the limit.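

In this assay, among the compounds shown here, compound 4 gives < 10000 nM, which is a limit of the assay and not a number, so no step from compound 3 to compound 4 can be read. The compounds shown leave open what fluoro in place of chloro on an aromatic carbon does to this inhibition.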